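Adding fluoro to compound 1

The compounds below may be only part of what the source reports. "The series", "measured", "known", "first", "only" and "open" are said of these compounds alone.

Measured in a functional assay on COLO 205 cells (Homo sapiens) for antiproliferative activity, read by WST assay, with a stated time of 3 days; a lower number here means a stronger inhibitor, a higher number a weaker inhibitor:
- compound 1 `O=c1cc(I)n([C@@H]2O[C@H](CO)[C@@H](O)[C@H]2O)c(=O)[nH]1`: > 50000 nM
- compound 2 `[N-]=[N+]=Nc1cc(=O)[nH]c(=O)n1[C@@H]1O[C@H](CO)[C@@H](O)[C@H]1O`: > 50000 nM
- compound 3 `CNc1cc(=O)[nH]c(=O)n1[C@@H]1O[C@H](CO)[C@@H](O)[C@H]1O`: > 50000 nM

Compound 1 stands at > 50000 nM, which is a limit and not a number. Compound 2 gives > 50000 nM, also a limit. Compound 3 gives > 50000 nM, again a limit. Together these make up (the limit of > 50000 nM in this assay, at which 3 of the 3 values shown sit).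

Compound 4 `O=c1[nH]c(=O)n([C@@H]2O[C@H](CO)[C@@H](O)[C@H]2O)c(I)c1F` keeps the core of compound 1 and differs from it in one place: fluoro in place of hydrogen on an aromatic carbon. This puts fluoro in place of hydrogen on an aromatic carbon, ortho to an iodo group.

The measured steps are a step that the two limits leave unreadable from compound 1 to compound 2, a step that the two limits leave unreadable from compound 1 to compound 3 and a step that the two limits leave unreadable from compound 2 to compound 3. They exchange the iodo, azido and methylamino groups, and none of them replaces this hydrogen, so they offer no size to carry over. Any shift in this assay can only be expected toward stronger inhibition, and compound 4 may well stay at a limit. The expected step, an at least 2.5-fold lower number from compound 1 to compound 4 (0.39 log units; beyond the scatter), is therefore a rough estimate. For compound 4 the estimated value is 20000 nM, with an expected range of 1500 nM to 50000 nM.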

Compound 4, half-maximal inhibitory concentration: > 50000 nM
Compound 4: no number, only a limit; the forecaster's own chance of this, stated with the estimate: 50%; at least 2.5-fold (0.39 log units) between middle value and limit.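

Compound 1 and compound 4 both end at a limit in this assay, so no size can be read for the step between them: the limit of > 50000 nM in this assay, at which 4 of the 4 values shown sit.

The compounds shown leave open how strongly any of them inhibits, and whether fluoro in place of hydrogen changes that at all.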